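A few compounds are considered here, and "the series" means these few. Any claim that something is new, unique, unknown or untested is made for them only; others in the source may bear on it.

Measured so far:
- compound 1, `COc1cc2c(cc1O)CN(CCCCNC(=O)c1ccc(-c3ccccc3)cc1)CC2`, in an assay on cells for displacement of a labelled ligand from D(4) dopamine receptor (Homo sapiens) (on this read-out higher numbers stand for weaker inhibition and lower numbers for stronger inhibition), compound 1 gives 720 nM
- compound 2, `COc1cc2c(cc1O)CN(CCCCNC(=O)c1ccc3ccccc3c1)CC2`, in this assay compound 2 gives 170 nM

The two compounds share the same core and the same four-carbon chain ending in an amide; they differ only in the aromatic group attached to the carbonyl carbon. Compound 2 has the lower of the two numbers, and its gap to compound 1 is larger than the usual scatter of repeated measurements, so compound 2 is the tighter binder of the pair.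

Compound 3, `COc1cc2c(cc1O)CN(CCCCNC(=O)c1ccc(F)cc1)CC2`, is not yet measured. It differs from compound 2 by 4-fluorophenyl in place of naphthalen-2-yl on a carbonyl carbon. Both aromatic groups lack hydrogen-bond donors and acceptors, so the change is mainly one of size. For the measured compounds named here, only two compounds give guidance, and both carry a larger aromatic group than compound 3 carries, so no step of this kind has been measured directly.

The number for compound 3 is expected to be higher than that of compound 2, a step of a 3.5-fold higher number from compound 2 to compound 3 (0.55 log units; beyond the scatter) that would reach beyond the scatter. The estimate for compound 3 is 600 nM, with a range from 150 nM to 2500 nM.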

Compound 3, inhibition constant: 95 nM
Beside the measured number, compound 3's estimate is 6.3-fold (0.80 log units) above it; the whole stated range lies above it.
By their numbers in this assay, from the lowest: compounds 3 and 2 (each within the scatter of the next); then compound 1.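

In this assay, 4-fluorophenyl in place of naphthalen-2-yl on the carbonyl carbon gives a 1.8-fold lower number from compound 2 to compound 3 (0.25 log units; within the scatter), so this pair cannot be told apart, and the larger group with its two aromatic rings brings no measurable gain here. Fluoro in place of phenyl on an aromatic carbon gives a 7.6-fold lower number from compound 1 to compound 3 (0.88 log units; beyond the scatter), which is a real difference and shows that this place does not accept every large aromatic group equally well, as group size alone does not sort these three compounds: naphthalen-2-yl stays within the scatter of 4-fluorophenyl, while the phenyl-bearing group of compound 1 does not. Nothing available explains why these aromatic groups compare as they do.

As far as these compounds go, whether the fluoro itself contributes stays open, and a plain phenyl on the carbonyl carbon, or a chlorine in place of the fluoro, would speak to that. From the compounds shown here alone, it is equally open how a longer chain than the four-carbon chain shared by these compounds would alter the picture.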